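Ring size on the thiocarbonyl: from piperidine to pyrrolidine

The compounds below may be only part of what the source reports. "The series", "measured", "known", "first", "only" and "open" are said of these compounds alone.

Of the compounds shown here, two sharing one core have been measured in a functional assay on MCF7 cells (Homo sapiens) for cytotoxicity, read by MTT assay, with a stated time of 72 h, tested at 100 uM; a higher number here means more inhibition of growth at the concentration tested, a lower number less inhibition of growth. Compound 1 `Cc1ccnc(/C(N)=N/NC(=S)N2CCOCC2)c1` carries a morpholin-4-yl group on the thiocarbonyl carbon and in this assay gives 12.8%. Compound 2 `Cc1ccnc(/C(N)=N/NC(=S)N2CCCCC2)c1` carries a piperidin-1-yl group in the same place and gives 80.1%, the higher of the two numbers; the change a number 67.3 percentage points higher from compound 1 to compound 2 (beyond the scatter) is large and clearly beyond the scatter.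

Compound 3 `Cc1ccnc(/C(N)=N/NC(=S)N2CCCC2)c1` is not yet measured. It differs from compound 2 in one place: pyrrolidin-1-yl in place of piperidin-1-yl on a thiocarbonyl carbon. Among the measured compounds shown here, the only step known so far, the one from compound 1 to compound 2, swapped one six-membered ring for another and shows that the group on the thiocarbonyl carbon can shift this assay strongly. For the measured compounds named here, no measured pair shows what a five-membered ring does there, so the direction of the step is uncertain, but a step of some size is plausible. For compound 3 a moderate decrease is expected, a number 20.1 percentage points lower from compound 2 to compound 3 (beyond the scatter), giving an estimate of 60% with a range from 25% to 90%.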

Compound 3, percent growth inhibition at one concentration: 87.7%
Compound 3: middle estimate off by 27.7 percentage points, on the low side; the range from low to high includes it.
By their numbers in this assay, from the lowest: compound 1; then compounds 2 and 3 (each within the scatter of the next).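

In this assay, putting pyrrolidin-1-yl in place of piperidin-1-yl on the thiocarbonyl carbon gives a number 7.6 percentage points higher from compound 2 to compound 3 (within the scatter), so this assay does not separate the five-membered ring from the six-membered one. Comparing the morpholin-4-yl group with the new ring gives a number 74.9 percentage points higher from compound 1 to compound 3 (beyond the scatter) as a second large step, and among these three compounds, only the one carrying morpholin-4-yl gives a low number. No measurement offered alongside these numbers explains why the three rings fall out this way.

The three rings leave open whether the high numbers extend to a seven-membered azepan-1-yl ring, to a piperazin-1-yl ring with its second nitrogen, or to an open-chain dimethylamino group on the same carbon. On these data alone, since all three compounds were tested at one concentration, it also remains open whether compound 2 and compound 3 would still be indistinguishable at lower concentrations, where a full dose-response curve could show a difference that a single test point cannot.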